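This account rests on a few compounds, and the source may have more. Where it says the series, first, only, none or still open, it means among the compounds named here.

Compound 1 `COc1cc(-c2c(C#N)c(-c3cccs3)nc3c2c(-c2ccccc2)nn3-c2ccccc2)ccc1O`, compound 2 `N#Cc1c(-c2cccs2)nc2c(c(-c3ccccc3)nn2-c2ccccc2)c1-c1ccc(O)cc1` and compound 3 `COc1cc(-c2c(C#N)c(-c3ccccc3)nc3c2c(-c2ccccc2)nn3-c2ccccc2)ccc1O` share one core and differ at two points. In a functional assay on MV4-11 cells (Homo sapiens) for antiproliferative activity, read by resazurin assay, with a stated time of 72 h (a higher number here means a weaker inhibitor, a lower number a stronger inhibitor), compound 1 gives 44200 nM and compound 2 gives 34200 nM. Compound 3 returns only a limit of the assay in this assay, > 50000 nM. The change hydrogen in place of methoxy on an aromatic carbon yields a 1.3-fold lower number from compound 1 to compound 2 (0.11 log units; within the scatter). The change phenyl in place of thiophen-2-yl on an aromatic carbon yields an at least 1.1-fold higher number from compound 1 to compound 3 (0.05 log units; that floor lies within the scatter), a floor set by the limit of > 50000 nM in this assay, at which 1 of the 3 values shown sits. Compound 4 `N#Cc1c(-c2ccccc2)nc2c(c(-c3ccccc3)nn2-c2ccccc2)c1-c1ccc(O)cc1` carries the change hydrogen in place of methoxy on an aromatic carbon on the core of compound 3, which differs from the core of compound 1 as told by phenyl in place of thiophen-2-yl on an aromatic carbon; the surroundings of the change read the same as between compound 1 and compound 2, so this is the same change. A step that the limit leaves unreadable from compound 3 to compound 4 is expected in this assay, set beside a 1.3-fold lower number from compound 1 to compound 2 (0.11 log units; within the scatter) and resting on that earlier step lying within scatter. Compound 4 is therefore expected at 55000 nM, between 25000 nM and 120000 nM, with a real chance that this assay again returns only a limit.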

Compound 4, half-maximal inhibitory concentration: 26100 nM
The estimate for compound 4 lay 2.1-fold (0.32 log units) above the measured number; the range from low to high includes it.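

In this assay the change from 4-hydroxy-3-methoxyphenyl to 4-hydroxyphenyl gives an at least 1.9-fold lower number from compound 3 to compound 4 (0.28 log units; that floor lies within the scatter), a floor only, so its true size on this core stays unfixed: the same change on two cores in this assay, a 1.3-fold lower number (0.11 log units; within the scatter) from compound 1 to compound 2 and an at least 1.9-fold lower number (0.28 log units; that floor lies within the scatter) from compound 3 to compound 4; the limit leaves it open whether they differ. Phenyl in place of thiophen-2-yl gives a 1.3-fold lower number from compound 2 to compound 4 (0.12 log units; within the scatter), and its other reading is also only a floor: the same change on two cores in this assay, an at least 1.1-fold higher number (0.05 log units; that floor lies within the scatter) from compound 1 to compound 3 and a 1.3-fold lower number (0.12 log units; within the scatter) from compound 2 to compound 4; the limit leaves it open whether they differ. Neither change is thus shown to carry across cores with the same size, nor shown to differ: the limit of > 50000 nM in this assay, at which 1 of the 4 values shown sits.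

The compounds shown leave open whether an amine or a carboxylic acid in place of the hydroxy group, or a longer chain in place of methoxy, would give a step beyond the scatter. They also leave open how both changes compare on cores where every value is a number.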